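Swapping a Benzothiazole for a Fused Amine Bicycle

The source may hold more compounds than are shown below. What is called first, only, known or untested is meant among the compounds shown, and "the series" means these compounds.

The account concerns two measured compounds and one that awaits its number. In an ADME assay on microsomes from liver (Homo sapiens) for metabolic stability, read by LC-MS, with a stated time of 10 min, tested at 0.5 uM (a higher number here means that more of the compound is left, a lower number that less of the compound is left), compound 1 `CN1CCN(CCCN(C[C@H]2Cc3ccccc3CN2)[C@H]2CCCc3cccnc32)CC1` gives 72%, while compound 2 `c1cnc2c(c1)CCC[C@@H]2N(CCCN1CCNCC1)Cc1nc2ccccc2s1` gives 50%. Going by the values given here, compound 2 thus stands lowest of the two numbers, with compound 1 the nearer neighbour and the gap between them beyond the scatter; no step between them is set out, so only the two values themselves are noted.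

Compound 3 `c1cnc2c(c1)CN[C@@H](CN(CCCN1CCNCC1)[C@H]1CCCc3cccnc31)C2` follows from compound 2 by one change: a group of 10 heavy atoms (8 carbon, 2 nitrogen; one six-membered non-aromatic ring with 1 hetero atom, one six-membered aromatic ring with 1 hetero atom) in place of a group of 9 heavy atoms (7 carbon, 1 nitrogen, 1 sulfur; one five-membered aromatic ring with 2 hetero atoms, one six-membered aromatic ring of carbon only), on a saturated chain carbon bound to an amine nitrogen.

The entering group resembles the corresponding part of compound 1, which reaches 72% in this assay, so a rise in this assay is expected from compound 2 to compound 3, of moderate size and probably beyond the scatter, estimated as a number 15 percentage points higher from compound 2 to compound 3 (beyond the scatter). On that basis compound 3 is expected to give 65% in this assay, within a range from 45% to 85%.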

Compound 3, percent of the compound remaining: 79%
Compound 3: the middle estimate sits 14 percentage points below what was measured; measured number inside the range.
By their numbers in this assay, from the lowest: compound 2; then compounds 1 and 3 (each within the scatter of the next).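

In this assay, the step at this position is a number 29 percentage points higher from compound 2 to compound 3 (beyond the scatter) and lies beyond the scatter. It comes with the loss of the 1,3-benzothiazol-2-yl group and the entry of a group with one six-membered non-aromatic ring with 1 hetero atom and one six-membered aromatic ring with 1 hetero atom, so the place on a saturated chain carbon bound to an amine nitrogen is now shown to matter for the percent of compound remaining. No measurement given here accounts for this rise.

Which part of the entering group goes with the higher number stays open: its hydrogen-bond donor, its ring nitrogen or its defined stereocentre. Also open, on these data alone, is how a single-ring group, such as a plain phenyl or a pyridin-2-yl, would behave at the same place.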